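Aryl substituent swap on an oxazole ketone inhibitor series

The source may report more compounds than this note shows. Statements on the series, on what has been measured and on what is new or still open speak of the compounds shown alone.

Measured compounds:
Compound 1 `O=C(CCCCCCc1ccccn1)c1ncc(-c2ccccn2)o1` — in an assay for inhibition of Fatty-acid amide hydrolase 1 (Rattus norvegicus) (on this read-out higher numbers stand for weaker inhibition and lower numbers for stronger inhibition), compound 1 gives 120 nM.
Compound 2 `Nc1cccc(CCCCCCC(=O)c2ncc(-c3ccccn3)o2)c1` — in this assay compound 2 gives 30 nM.

Compound 2 holds the lowest number of the two; the step of a 4.0-fold lower number from compound 1 to compound 2 (0.60 log units; beyond the scatter) separates it from compound 1. Compound 3 `O=C(CCCCCCc1cccc(C(F)(F)F)c1)c1ncc(-c2ccccn2)o1` keeps the shared core of compound 2 and differs only by trifluoromethyl in place of amino on an aromatic carbon, which sits on an aromatic carbon of a six-membered aromatic ring of carbon only, meta to a large group. Going by the values given here, the one measured step concerns the exchange of the whole terminal ring and does not bear on a change of substituent on a retained ring, so no direct guide exists. Compound 2 anchors the estimate; for compound 3 a step of a 2.0-fold higher number from compound 2 to compound 3 (0.30 log units; within the scatter) in this assay is expected, pointing toward a somewhat higher number. Compound 3 is estimated at 60 nM, within 15 nM to 250 nM.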

Compound 3, inhibition constant: 1 nM
Beside the measured number, compound 3's estimate is 60-fold (1.78 log units) above it, outside the stated range (below it).
By their numbers in this assay, from the lowest: compound 3; then compound 2; then compound 1.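

With the terminal ring kept, the substituent on its aromatic carbon, meta to a large group, proves far from indifferent in this assay: trifluoromethyl in place of amino gives a 30-fold lower number from compound 2 to compound 3 (1.48 log units; beyond the scatter). The earlier pair exchanged the whole terminal ring and could not show this effect of a single substituent on a retained ring. Here, a group counted with a hydrogen-bond donor and acceptor gives way to a larger one with neither, but no available measurement explains the size of this step.

The compounds shown leave open whether a chlorine, a methyl or a methoxy group on that same carbon would give a number nearer that of compound 2 or compound 3. They also leave open whether trifluoromethyl would hold its effect on another carbon of the ring or with a shorter chain.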